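Phenyl for thiophenyl on a dichloroacetamide core

The source may hold more compounds than are shown below. What is called first, only, known or untested is meant among the compounds shown, and "the series" means these compounds.

The study concerns dichloroacetanilides carrying an aryl group on the anilide ring. Compound 1, `O=C(Nc1cccc(-c2ccsc2)c1)C(Cl)Cl`, bears a thiophen-3-yl group. In a functional assay on NCI-H460 cells (Homo sapiens) for cytotoxicity, read by MTT assay, with a stated time of 68 h (on this read-out lower numbers stand for stronger inhibition and higher numbers for weaker inhibition), compound 1 reaches only the limit of the assay and gives > 50000 nM. Its standing among the numbers shown is therefore known only as the limit of > 50000 nM in this assay, at which 1 of the 2 values shown sits. Compound 2, `O=C(Nc1cccc(-c2ccc(-c3ccccc3)cc2)c1)C(Cl)Cl`, carries a biphenyl group in the same place, and in this assay compound 2 gives 10900 nM. Compound 3, `O=C(Nc1cccc(-c2ccccc2)c1)C(Cl)Cl`, is not yet measured; it differs from compound 1 by phenyl in place of thiophen-3-yl on an aromatic carbon. Going by the values given here, no measured pair of compounds differing in one place is available, so the step in this assay from compound 1 to compound 3 cannot be anchored; the author expects at most a modest change, if any, beyond the scatter, with a lower number not excluded. The expected step is an at least 1.2-fold lower number from compound 1 to compound 3 (0.09 log units; that floor lies within the scatter). For compound 3 the author estimates 40000 nM, in a range from 12000 nM to 150000 nM.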

Compound 3, half-maximal inhibitory concentration: 20200 nM
Estimate against measurement, compound 3: 2.0-fold (0.30 log units) above; low and high end bracket the measured number.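

With phenyl in place of thiophen-3-yl on the aromatic carbon, this assay shows an at least 2.4-fold lower number from compound 1 to compound 3 (0.39 log units; beyond the scatter), so the ring at this position does matter to the read-out. That step is only a bound, because compound 1 stands at a limit of the assay: the limit of > 50000 nM in this assay, at which 1 of the 3 values shown sits. Hydrogen in place of phenyl on the aromatic carbon gives a 1.9-fold higher number from compound 2 to compound 3 (0.27 log units; within the scatter), so the outer phenyl of compound 2 brings no change that can be separated from the scatter.

The compounds shown leave open whether a non-aromatic group at this place, such as an amine, a carboxylic acid or a longer alkyl chain, would hold the number of compound 3. They also leave open how a phenyl ring carrying a small substituent, such as methoxy or chlorine, would read here.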